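This account rests on a few compounds, and the source may have more. Where it says the series, first, only, none or still open, it means among the compounds named here.

Three compounds of a shared core, each carrying a five-carbon chain from a ring nitrogen to an aryl ether, were tested in an ADME assay on HEL cells (Homo sapiens) for cytotoxicity; a lower number here means that less compound is tolerated, a higher number that more compound is tolerated. Compound 1, `Cc1ccccc1OCCCCCn1ccc(=O)[nH]c1=O`, gives > 100000 nM, and this value is a limit of the assay rather than a number. Compound 2, `N#Cc1ccc(OCCCCCn2ccc(=O)[nH]c2=O)cc1`, gives 100000 nM in this assay. Compound 3, `O=C(O)c1ccc(OCCCCCn2ccc(=O)[nH]c2=O)cc1`, stands apart: its result in this assay is "not determined" (no result reported), so no number is known for it, and it is compound 2 and compound 1 that set the scale. What the measured values show is the limit of > 100000 nM in this assay, at which 1 of the 3 values shown sits, with the other value sitting at the same concentration as a number.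

The step from compound 3 leads to compound 4, `Cc1ccc(OCCCCCn2ccc(=O)[nH]c2=O)cc1`. The change is methyl in place of carboxy on an aromatic carbon. Within the data shown here, no measured pair differs in a single place, so no step size can be read off directly. Since the two known values sit together at the top of the range, the expectation for compound 4 is a value in this assay that again lies at the ceiling, with no shift beyond the scatter in either direction. Compound 4 is therefore estimated to give 100000 nM, within a range from 50000 nM to 200000 nM.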

Compound 4, half-maximal cytotoxic concentration: > 100000 nM
Compound 4: no number, only a limit; the forecaster's own chance of this, stated with the estimate: 60%; the middle value sits exactly at the limit.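

In this assay compound 4 gives > 100000 nM, which is a limit of the assay and not a number. This shows that methyl on this aromatic carbon, para to a large group, does not bring the result down to a number within the range of the assay, and the same holds for the methyl group of compound 1 in its own position on the ring. Methyl in place of cyano on an aromatic carbon gives a number no lower from compound 2 to compound 4 (the limit leaves the size open). The step that reaches compound 4 from compound 1 cannot be read, as the two limits leave it open. More of the small series now rests at the top of the assay, so the values separate the compounds hardly at all: the limit of > 100000 nM in this assay, at which 2 of the 4 values shown sit.

Going by these compounds, compound 3 has no reported result, so what the carboxylic acid does at this place compared with methyl remains unknown. On these data alone, it also remains open whether any other change, such as an amine on the aromatic ring or a longer chain between the ring and the shared core, would give a number clearly lower than the top of the range.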